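Swapping Phenyl for Methyl on a Shared Core

The source may hold more compounds than are shown below. What is called first, only, known or untested is meant among the compounds shown, and "the series" means these compounds.

Of the compounds shown here, three built on one shared core have been measured in a functional assay on HTB-54 cells (Homo sapiens) for cytotoxicity, read by MTT assay, with a stated time of 72 h; a higher number here means a weaker inhibitor of growth, a lower number a stronger inhibitor of growth. Compound 1 `C=CCOC(=O)Nc1ccc([Se]C#N)cc1` gives 50100 nM, compound 2 `CCCOC(=O)Nc1ccc([Se]C#N)cc1` gives 51900 nM, and compound 3 `N#C[Se]c1ccc(NC(=O)OCc2ccccc2)cc1` gives 50800 nM. Compound 3 stands second highest of the three numbers, nearest to compound 1 and furthest from compound 2, and both of those gaps lie within the scatter. The steps among the measured compounds are all flat: a 1.0-fold higher number from compound 1 to compound 2 (0.02 log units; within the scatter), a 1.0-fold higher number from compound 1 to compound 3 (0.01 log units; within the scatter) and a 1.0-fold lower number from compound 2 to compound 3 (0.01 log units; within the scatter). Compound 4 `CCOC(=O)Nc1ccc([Se]C#N)cc1` has not yet been measured in this assay; it differs from compound 3 as follows: methyl in place of phenyl on a saturated chain carbon bound to an oxygen next to a carbonyl group. The step that bears most directly on this change is the one that replaced ethyl with phenyl at the same place, and it moved nothing beyond the scatter; the two other steps, each also a change at that place, were equally flat. On that basis no movement beyond the scatter is expected, a 1.0-fold higher number from compound 3 to compound 4 (0.00 log units; within the scatter). Compound 4 is therefore estimated at 51000 nM, with a range from 25000 nM to 100000 nM.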

Compound 4, concentration for total growth inhibition: 49300 nM
Compound 4: the middle estimate sits 1.0-fold (0.01 log units) above what was measured; measured number inside the range.
By their numbers in this assay, from the lowest: compounds 4, 1, 3 and 2 (each within the scatter of the next).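

In this assay, methyl in place of phenyl on the saturated chain carbon bound to an oxygen next to a carbonyl group leaves the number within the scatter (a 1.0-fold lower number from compound 3 to compound 4 (0.01 log units; within the scatter)), so removing the aromatic ring altogether makes no readable difference. Methyl also reads level with the two other groups at this place, ethyl (a 1.1-fold lower number from compound 2 to compound 4 (0.02 log units; within the scatter)) and vinyl (a 1.0-fold lower number from compound 1 to compound 4 (0.01 log units; within the scatter)), which extends the flat picture to the smallest group shown there and to four compounds in all. No evidence is at hand to explain this flatness.

All four groups shown are built of carbon and hydrogen only, so it remains open whether an amine or a carboxylic acid at this place would move the number. A much longer chain is equally untested here, as is any change elsewhere on the shared core.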